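A few compounds are considered here, and "the series" means these few. Any claim that something is new, unique, unknown or untested is made for them only; others in the source may bear on it.

Two close analogues of a shared spiro core have been run in a functional assay on HepG2 cells (Homo sapiens) for antiproliferative activity, read by MTT assay, with a stated time of 48 h; on this read-out higher numbers stand for weaker inhibition and lower numbers for stronger inhibition. Compound 1 `Cc1ccc(-n2nncc2CN2C(=O)C3(C(C#N)=C(N)Oc4c3c3nc5ccccc5nc3c3ccccc43)c3ccccc32)cc1C` is one of them; in this assay compound 1 returns only a limit, > 50000 nM, not a number. Going by the values given here, compound 2 `N#CC1=C(N)Oc2c(N)cc3nc4ccccc4nc3c2C12C(=O)N(Cc1cnnn1-c1ccccc1Cl)c1ccccc12` carries a primary amine on the fused aromatic core and a 2-chlorophenyl group on the triazole; in this assay compound 2 gives 33500 nM, the only numerical value in the set so far. The remaining value sits at the limit, (the limit of > 50000 nM in this assay, at which 1 of the 2 values shown sits), so compound 2 stands as the one measurable point and the series is weak throughout.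

The next compound, compound 3 `N#CC1=C(N)Oc2c(N)cc3nc4ccccc4nc3c2C12C(=O)N(Cc1cnnn1-c1ccc(F)c(Cl)c1)c1ccccc12`, keeps the aminated core of compound 2 and alters only the aryl group on the triazole nitrogen: 3-chloro-4-fluorophenyl in place of 2-chlorophenyl on an aromatic nitrogen. Among the compounds with values here, no measured pair differing in one place exists yet, so the size of this step cannot be anchored on precedent. Compound 3 is expected to stay close to compound 2, with an anticipated step of a 1.1-fold lower number from compound 2 to compound 3 (0.05 log units; within the scatter) within the usual scatter rather than a clear shift in either direction. Compound 3 is estimated at 30000 nM, most likely between 12000 nM and 75000 nM.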

Compound 3, half-maximal inhibitory concentration: > 50000 nM
Compound 3: only a limit was reported; the forecaster's own chance of this, stated with the estimate: 35%; at least 1.6-fold (0.22 log units) between middle value and limit.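

Going by these compounds alone, the exchange of 2-chlorophenyl for 3-chloro-4-fluorophenyl, on an aromatic nitrogen of the five-membered ring, gives the first pair that differs in one place. Read in this assay, the pair yields only a floor, an at least 1.4-fold higher number from compound 2 to compound 3 (0.17 log units; that floor lies within the scatter), so the new aryl group brings no lower number, and the real size of the step stays unknown as compound 3 gives a limit and not a number. Compound 2 remains the only measurable point, and the rest of the set sits at the limit: the limit of > 50000 nM in this assay, at which 2 of the 3 values shown sit.

As far as these compounds go, what a carboxylic acid, a dimethylamino group or no substituent at all on this aromatic ring would do to the number remains open, as does whether any change here can move the value clearly away from that of compound 2. The part played by the primary amine on the core also stays open: compound 1 and compound 2 differ in more than one place, and no pair shown isolates that amine.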